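This account rests on a few compounds, and the source may have more. Where it says the series, first, only, none or still open, it means among the compounds named here.

Measured so far in an assay on cells for antagonist activity at transient receptor potential cation channel subfamily V member 4 (Rattus norvegicus), read by FLIPR and calcium flux, with a stated time of 10 min; a lower number here means a stronger inhibitor, a higher number a weaker inhibitor: compound 1 `COc1ccc(-c2nc3ccccc3c(C(=O)N[C@@H](C)c3ccccc3)c2CN2CCC(N3CCCCC3)CC2)cc1` gives 320 nM; compound 2 `CC(C)[C@H](NC(=O)c1c(CN2CCC(N3CCCCC3)CC2)c(-c2cccc(C(F)(F)F)c2)nc2ccccc12)c1ccccc1` gives 25 nM; compound 3 `O=C(NC1(c2ccccc2)CC1)c1c(CN2CCC(N3CCCCC3)CC2)c(-c2cccc(C(F)(F)F)c2)nc2ccccc12` gives 2.5 nM.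

Compound 1 stands highest of the three numbers. Compound 4 `Cc1ccc(-c2nc3ccccc3c(C(=O)N[C@@H](C)c3ccccc3)c2CN2CCC(N3CCCCC3)CC2)cc1` differs from it by methyl in place of methoxy on an aromatic carbon. Among the measured compounds shown here, the only measured step, a 10-fold lower number from compound 2 to compound 3 (1.00 log units; beyond the scatter), concerns the amide substituent and leaves the aryl group untouched, so no measured step bears on this change, and compounds 2 and 3 differ from compound 1 in more than one place. With nothing to point either way, the step of a 1.1-fold lower number from compound 1 to compound 4 (0.03 log units; within the scatter) in this assay is expected to lie within the usual scatter. Compound 4 is estimated at 300 nM, with a range from 100 nM to 1000 nM.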

Compound 4, half-maximal inhibitory concentration: 100 nM
The estimate for compound 4 lay 3.0-fold (0.48 log units) above the measured number; low and high end bracket the measured number.
By their numbers in this assay, from the lowest: compound 3; then compound 2; then compound 4; then compound 1.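

In this assay the change from 4-methoxyphenyl to 4-methylphenyl brings a 3.2-fold lower number from compound 1 to compound 4 (0.51 log units; beyond the scatter) and shows that the substituent on this aromatic carbon, para to a large group, affects the number, whereas the earlier step concerned only the amide substituent. Nothing measured here accounts for the step.

The compounds shown leave open how a chloro, hydroxyl or amino group would fare at this place. They also leave open whether the same change would give a similar step with the amide substituent of compound 3.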